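Adding fluoro to a compound already at the limit

A few compounds are considered here, and "the series" means these few. Any claim that something is new, unique, unknown or untested is made for them only; others in the source may bear on it.

In an ADME assay on HEK293 cells (Homo sapiens) for cytotoxicity, read by MTT assay, with a stated time of 36 h (a higher number here means a weaker inhibitor, a lower number a stronger inhibitor), compound 2 `O=C(c1ccc2c(c1)OCCO2)C1CCN(Cc2coc(-c3ccccc3)n2)CC1` gives > 150 ug/mL, which is a limit and not a number. Compound 1 `O=C(c1ccc2c(c1)OCCO2)C1CCN(Cc2coc(-c3ccc(F)cc3)n2)CC1` gives > 150 ug/mL, also a limit. Everything measured so far rests on (the limit of > 150 ug/mL in this assay, at which 2 of the 2 values shown sit). Compound 3 `O=C(c1ccc2c(c1)OCCO2)C1CCN(Cc2coc(-c3cccc(F)c3)n2)CC1` differs from compound 2 by one change: fluoro in place of hydrogen on an aromatic carbon. Going by the values given here, the only measured step involving such a swap is a step that the two limits leave unreadable from compound 1 to compound 2, so it offers no size to carry over. No change beyond the scatter is expected in this assay. The expected step is a step that the limit leaves unreadable from compound 2 to compound 3. Compound 3 is estimated at 180 ug/mL, with an expected range of 120 ug/mL to 300 ug/mL.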

Compound 3, half-maximal inhibitory concentration: > 150 ug/mL
Compound 3 gave a limit, no number (the forecaster's own chance of this, stated with the estimate: 85%); the middle value lies beyond the limit too.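

No step among compound 1, compound 2 and compound 3 can be read in this assay, since all three stop at the same limit: the limit of > 150 ug/mL in this assay, at which 3 of the 3 values shown sit.

On these data alone, how far beyond that limit each compound lies, and whether fluoro or its place matters here, stays open.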